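The source may hold more compounds than are shown below. What is called first, only, known or untested is meant among the compounds shown, and "the series" means these compounds.

Measured compounds:
compound 1 `COc1cc(NC(C)CCCNC(=O)NNC(=O)/C=C/c2ccc(OC)c(OC)c2)c2ncccc2c1`: 37000 nM
compound 2 `COc1cc(NC(C)CCCNC(=O)NNC(=O)NCCCO)c2ncccc2c1`: "not determined" (no result reported)

In an ADME assay on L6 cells (Rattus norvegicus) for cytotoxicity, read by resazurin assay, with a stated time of 70 h (a higher number here means a weaker inhibitor, a lower number a stronger inhibitor), compound 1 gives 37000 nM, which places it among the weak inhibitors of the series. Compound 2 shares the core of compound 1 but carries a (3-hydroxypropyl)carbamoyl group in place of the cinnamoyl-type tail; in this assay compound 2 gives "not determined" (no result reported), so it has no single number to stand on, and its position relative to compound 1 cannot be read from the data.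

Compound 3 `COc1cc(NC(C)CCCNC(=O)NNC(=O)N(CCO)CCO)c2ncccc2c1` differs from compound 2 by one change, (bis(2-hydroxyethyl)amino in place of (3-hydroxypropyl)amino on a carbonyl carbon). Among the compounds with values here, no step between two measured compounds is recorded for this change, so its size is not known from the series. The change is small in count and keeps the same kind of tail, and compound 3 is therefore expected to sit in the same weak range as compound 1, with no step beyond the usual scatter in either direction.

For compound 3 in this assay the estimated value is 60000 nM, expected to fall between 20000 nM and 200000 nM.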

Compound 3, half-maximal inhibitory concentration: 178000 nM
The estimate for compound 3 lay 3.0-fold (0.47 log units) below the measured number; the measured number falls inside the stated range.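

On the carbonyl carbon, the tail now has a readable effect in this assay: bis(2-hydroxyethyl)amino in place of 2-(3,4-dimethoxyphenyl)ethenyl gives a 4.8-fold higher number from compound 1 to compound 3 (0.68 log units; beyond the scatter), a modest step beyond the scatter and the first comparison available in the series. This single step shows that the read-out responds to a change at this position and that the number moves upward with this replacement, although it swaps a tail with a ring for one without, so it cannot assign the shift to any one feature of either tail. The nearer comparison, (3-hydroxypropyl)amino to bis(2-hydroxyethyl)amino, cannot be read, as compound 2 has no number, and no measurement on hand accounts for the rise seen with compound 3.

Still open, on these data alone, is whether the ring of the 2-(3,4-dimethoxyphenyl)ethenyl tail, its two methoxy groups or its ethenyl link carries the lower number of compound 1, which a plain phenyl or a saturated ethyl link on the same carbonyl carbon would help separate. Also open, as far as these compounds go, is where a tail ending in a carboxylic acid, a tertiary amine or a longer alkyl chain would fall relative to compound 1 and compound 3.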